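A few compounds are considered here, and "the series" means these few. Any claim that something is new, unique, unknown or untested is made for them only; others in the source may bear on it.

Measured compounds:
compound 1 `CCN(Cc1ccccc1)C(=O)C1CCN(S(=O)(=O)c2ccccc2OC)CC1` — "not determined" (no result reported) in a functional assay on CHO cells for positive allosteric modulation of muscarinic acetylcholine receptor M5 (Homo sapiens), read by calcium flux; a lower number here means a smaller maximal response, a higher number a larger maximal response;
compound 2 `CCN(Cc1ccccc1)C(=O)C1CCN(S(=O)(=O)c2ccncc2)CC1` — "not determined" (no result reported) in this assay;
compound 3 `CCN(Cc1ccccc1)C(=O)C1CCN(S(=O)(=O)c2ccc3cccnc3c2)CC1` — 66% in this assay.

Compound 1 stands without a single number in this assay, and compound 2 is a further entry without one; only compound 3 carries a value. The step to compound 4 `CCN(Cc1ccccc1)C(=O)C1CCN(S(=O)(=O)c2ccc3nsnc3c2)CC1` changes the group on the sulfonyl sulfur: a group of 9 heavy atoms (6 carbon, 2 nitrogen, 1 sulfur; one five-membered aromatic ring with 3 hetero atoms, one six-membered aromatic ring of carbon only) in place of a group of 8 heavy atoms (7 carbon, 1 oxygen; one six-membered aromatic ring of carbon only), on a sulfonyl sulfur. For the measured compounds named here, with no number for compound 1, no step in this assay can be measured or sized against the scatter, and the direction of any change is unknown. Going by the values given here, the sole reference is the value of compound 3, which also carries a two-ring aromatic group on the sulfonyl sulfur. On that basis compound 4 is expected to reach 60%, with a likely range from 30% to 95%.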

Compound 4, largest response reached (reported as percent of maximum), in percent of the reference or control that the assay uses: 81%
Compound 4: middle estimate off by 21 percentage points, on the low side, within the range that was stated.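

The sulfonyl sulfur position now has its first measurable step: in this assay, replacing one two-ring aromatic group with another gives a number 15 percentage points higher from compound 3 to compound 4 (beyond the scatter). Both compounds keep a clear maximal response, so this position tolerates at least these two groups, and the choice between them changes the read-out. Steps involving compound 1 or compound 2 cannot be read. No measurement given here explains the difference.

From the compounds shown here alone, it remains open whether a single-ring group such as phenyl can support a response. A naphthyl group would show whether the hetero atoms of the two-ring groups matter.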